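Aryl halide swap on the triazole arm of compound 1

This account rests on a few compounds, and the source may have more. Where it says the series, first, only, none or still open, it means among the compounds named here.

For the measured compounds named here, compound 1 `C=C1C(=O)[C@]23C[C@@]1(O)CC[C@H]2c1ccc(OS(=O)(=O)c2ccc(C)cc2)c(C)c1[C@@H]3Cn1cc(-c2ccc(Br)cc2)nn1` is the only member of the set with a number: in a functional assay on SMMC-7721 cells (Homo sapiens) for cytotoxicity, read by MTT assay, with a stated time of 4 days (on this read-out lower numbers stand for stronger inhibition and higher numbers for weaker inhibition), compound 1 gives 4320 nM. Compound 2 `Cc1c(O)ccc2c1[C@H](Cn1cc(-c3ccc(Cl)cc3)nn1)[C@@]13CC(=O)[C@@](C)(CC[C@@H]21)C3` returns only a limit in this assay, > 20000 nM. Compound 3 `C=C1C[C@]23C[C@@]1(O)CC[C@H]2c1ccc(OS(=O)(=O)c2ccc(C)cc2)c(C)c1[C@@H]3Cn1cc(-c2ccc(C)cc2)nn1` likewise reaches only a limit in this assay, > 20000 nM. Most results are therefore limits: the limit of > 20000 nM in this assay, at which 2 of the 3 values shown sit. Compound 4 `C=C1C(=O)[C@]23C[C@@]1(O)CC[C@H]2c1ccc(OS(=O)(=O)c2ccc(C)cc2)c(C)c1[C@@H]3Cn1cc(-c2ccc(F)cc2)nn1` differs from compound 1 by fluoro in place of bromo on an aromatic carbon. Going by the values given here, no measured pair isolates this change; the expected step is a modest loss, a 1.9-fold higher number from compound 1 to compound 4 (0.27 log units; within the scatter), with a fair chance that only a limit is reported. Compound 4 is estimated at 8000 nM, within a range from 2500 nM to 20000 nM.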

Compound 4, half-maximal inhibitory concentration: 4280 nM
Compound 4: the middle estimate sits 1.9-fold (0.27 log units) above what was measured; measured number inside the range.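

In this assay fluoro in place of bromo, on an aromatic carbon para to a large group, gives a 1.0-fold lower number from compound 1 to compound 4 (0.00 log units; within the scatter) and so separates these two halogens by nothing readable at this place. Compound 4 also returns a number and not a limit, which counts in a set where limits are common: the limit of > 20000 nM in this assay, at which 2 of the 4 values shown sit.

For the compounds shown here, compounds 2 and 3 differ from compound 1 in more than one place, so no step to them can be read. As far as these compounds go, whether a methoxy group or an amine on this carbon would hold the reading stays open.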